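The compounds below may be only part of what the source reports. "The series", "measured", "known", "first", "only" and "open" are said of these compounds alone.

Of the compounds shown here, three built on a shared core have been tested in a toxicity assay on MDCK cells (Canis lupus familiaris) for cytotoxicity, read by crystal violet staining, with a stated time of 48 h; a lower number here means that less compound is tolerated, a higher number that more compound is tolerated. Compound 1 `CCOc1ccc(CN(Cc2ccc(C(C)(C)C)cc2)Cc2cc3cc(C)ccc3[nH]c2=O)cc1` gives in this assay only a limit of the assay, > 10000 nM. Compound 2 `Cc1ccc2[nH]c(=O)c(CN(Cc3ccc(C(C)(C)C)cc3)[C@H](CO)c3ccccc3)cc2c1` likewise gives only a limit, > 10000 nM. Compound 3 `COc1ccc(C(C)N(Cc2ccc(C(C)(C)C)cc2)Cc2cc3cc(C)ccc3[nH]c2=O)cc1` also gives only a limit, > 5000 nM. With every value a limit, the steps a step that the two limits leave unreadable from compound 1 to compound 2, a step that the two limits leave unreadable from compound 1 to compound 3 and a step that the two limits leave unreadable from compound 2 to compound 3 cannot be read in size or direction; the values sit at the limit of > 10000 nM in this assay, at which 2 of the 3 values shown sit, and (the limit of > 5000 nM in this assay, at which 1 of the 3 values shown sits). Compound 3 therefore stands at a limit, and the two compounds beside it stand at a limit as well. Compound 4 `Cc1ccc2[nH]c(=O)c(CN(Cc3ccc(C(C)(C)C)cc3)C(C)c3ccc(OC(F)F)cc3)cc2c1` differs from compound 3 by difluoromethyl in place of methyl on an oxygen on an aromatic ring. Within the data shown here, no measured step bears on this change in a readable way, since each step joins two limits. The expected step from compound 3 to compound 4 in this assay is a step that the limit leaves unreadable from compound 3 to compound 4, which is none beyond the scatter, and a limit is again the likely outcome. Compound 4 is estimated at 10000 nM, within 5000 nM to 30000 nM.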

Compound 4, half-maximal cytotoxic concentration: > 5000 nM
Compound 4: a limit, no number; the forecaster's own chance of this, stated with the estimate: 80%; the middle value is on the limit's open side.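

In this assay compound 4 gives only a limit, > 5000 nM. Its steps from compound 1, compound 2 and compound 3 each join two limits and cannot be read. Still open, from the compounds shown here alone, is the half-maximal cytotoxic concentration of all four compounds, and whether difluoromethyl in place of methyl shifts it.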